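A Carboxymethoxy Variant of Compound 1

A few compounds are considered here, and "the series" means these few. Any claim that something is new, unique, unknown or untested is made for them only; others in the source may bear on it.

Compound 1 `Cc1nc(-c2ccc(C(F)(F)F)cc2)sc1CNc1ccc(CC(=O)O)cc1` gives < 10000 nM in a functional assay on CHO cells for agonist activity at Free fatty acid receptor 1 (Homo sapiens) (a lower number here means that less compound is needed, a higher number that more compound is needed for the effect), which is a limit of the assay and not a number.
Compound 2 `O=C(O)CCCc1ccc(NCc2cccc(Oc3ccccc3)c2)cc1` gives 1120 nM in this assay.
Compound 3 `O=C(O)COc1ccc(NCc2cccc(Oc3ccccc3)c2)cc1` gives 2040 nM in this assay.

Compound 1 therefore stands only at a limit, and the data place it no more precisely than that (the limit of < 10000 nM in this assay, at which 1 of the 3 values shown sits). Compound 4 `Cc1nc(-c2ccc(C(F)(F)F)cc2)sc1CNc1ccc(OCC(=O)O)cc1` differs from compound 1 in one place: carboxymethoxy in place of carboxymethyl on an aromatic carbon. For the measured compounds named here, one measured step bears on this change. Between compound 2 and compound 3 a carboxyalkyl chain on an aromatic carbon is likewise replaced by carboxymethoxy, and that step, a 1.8-fold higher number from compound 2 to compound 3 (0.26 log units; within the scatter), lies within the scatter. Compound 1 is only known as a limit, so the starting point of the step is itself uncertain. On the evidence of the measured step, compound 4 is expected to land near the limit of compound 1, and the step that the limit leaves unreadable from compound 1 to compound 4 is expected to be no larger than the scatter. Compound 4 is accordingly estimated at 3000 nM, with a range from 600 nM to 10000 nM.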

Compound 4, half-maximal effective concentration: 288 nM
For compound 4 the middle estimate is 10-fold (1.02 log units) above the measured one; the whole stated range lies above it.
By their numbers in this assay, from the lowest: compound 4; then compounds 2 and 3 (each within the scatter of the next).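

The step from compound 1 to compound 4 cannot be read, because the value of compound 1 is a limit of the assay and not a number: the limit of < 10000 nM in this assay, at which 1 of the 4 values shown sits.

The compounds shown leave open how far carboxymethoxy in place of carboxymethyl on the core of compound 1 shifts the number in this assay, or in which direction.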